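The compounds below may be only part of what the source reports. "The series", "measured", "known", "first", "only" and "open" are said of these compounds alone.

Working notes on the series. Compound 1 `CC(C)Cc1nn(-c2cccc(F)c2)cc1C(=O)NCc1ccc(F)cc1` carries the shared core with 3-fluorophenyl on the aromatic nitrogen and 4-fluorobenzyl on the amide nitrogen. In a toxicity assay on HepG2 2.2.15 cells (Homo sapiens) for cytotoxicity, read by CCK-8 assay, with a stated time of 8 days (a higher number here means that more compound is tolerated, a lower number that less compound is tolerated), compound 1 gives > 100000 nM, which is a limit of the assay and not a number. Compound 2 `CCOC(=O)c1cn(-c2ccc([N+](=O)[O-])cc2)nc1CC(C)C` is measured in the same way; in this assay compound 2 gives > 100000 nM, again a limit. Compound 3 `CC(C)Cc1nn(-c2nccs2)cc1C(=O)NCc1ccc(F)cc1` has 1,3-thiazol-2-yl in place of 3-fluorophenyl on the aromatic nitrogen; in this assay compound 3 gives > 100000 nM, also a limit. Compound 1 thus stands only at a limit, and the two further values shown are limits as well: the limit of > 100000 nM in this assay, at which 3 of the 3 values shown sit. Going by the values given here, the single step between measured compounds, a step that the two limits leave unreadable from compound 1 to compound 3, has no readable size for that reason.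

Compound 4 `CC(C)Cc1nn(-c2cccc(F)c2)cc1C(=O)NCc1ccncc1` differs from compound 1 by pyridin-4-yl in place of 4-fluorophenyl on a saturated chain carbon bound to an amide-type nitrogen; cut one bond further out, 4-fluorobenzyl becomes (pyridin-4-yl)methyl. Among the compounds with values here, no measured step touches this position, and the one step measured elsewhere on the core leaves tolerance at the limit. The expectation is that a number no higher from compound 1 to compound 4 (the limit leaves the size open) amounts to no step beyond the scatter. For compound 4 the estimate in this assay is 100000 nM, with a range from 30000 nM to 300000 nM.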

Compound 4, half-maximal cytotoxic concentration: > 100000 nM
Compound 4: a limit, no number; the forecaster's own chance of this, stated with the estimate: 85%; the middle value lies on the limit itself.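

In this assay compound 4 gives > 100000 nM, a limit and not a number, so no size can be read for its step from compound 1. The compounds shown leave open at what concentration any of them stops being tolerated, and whether either change on the shared core shifts that concentration: the limit of > 100000 nM in this assay, at which 4 of the 4 values shown sit.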